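A few compounds are considered here, and "the series" means these few. Any claim that something is new, unique, unknown or untested is made for them only; others in the source may bear on it.

Measured so far in a functional assay on MCF7 cells (Homo sapiens) for antiproliferative activity, read by MTT assay, with a stated time of 72 h; a lower number here means a stronger inhibitor, a higher number a weaker inhibitor:
- compound 1 `COc1ccc(C(=O)O[C@H]2CC[C@]3(C)[C@H](CC[C@@](C)(O)[C@H]3CC[C@@H]3C(C)=CC[C@H]4[C@H](CC[C@]4(C)O)C3(C)C)OC2(C)C)cc1`: 41700 nM
- compound 2 `CC1=CC[C@H]2[C@H](CC[C@]2(C)O)C(C)(C)[C@@H]1CC[C@H]1[C@]2(C)CC[C@H](OC(=O)c3cccc([N+](=O)[O-])c3)C(C)(C)O[C@H]2CC[C@@]1(C)O`: 36000 nM

Compound 2 stands at 36000 nM and compound 1 at 41700 nM, so the two values lie within the scatter of each other and neither can be ranked above the other. Compound 3 `CC1=CC[C@H]2[C@H](CC[C@]2(C)O)C(C)(C)[C@@H]1CC[C@H]1[C@]2(C)CC[C@H](OC(=O)c3ccccc3C(F)(F)F)C(C)(C)O[C@H]2CC[C@@]1(C)O` keeps the shared core and ester link of compound 2. The change is 2-(trifluoromethyl)phenyl in place of 3-nitrophenyl on a carbonyl carbon.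

Within the data shown here, only one measured step bears on this change: 3-nitrophenyl in place of 4-methoxyphenyl on a carbonyl carbon, which gave a 1.2-fold lower number from compound 1 to compound 2 (0.06 log units; within the scatter). Among the measured compounds shown here, that single step is the whole evidence, and no measured compound carries 2-(trifluoromethyl)phenyl. With so little to go on, no step beyond the scatter is expected in this assay, and no direction can be argued. The expected change is a 1.1-fold higher number from compound 2 to compound 3 (0.02 log units; within the scatter). For compound 3 the estimated value is 38000 nM, with an expected range of 15000 nM to 90000 nM.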

Compound 3, half-maximal inhibitory concentration: 19200 nM
Compound 3: middle estimate off by 2.0-fold (0.30 log units), on the high side; the measured number falls inside the stated range.
By their numbers in this assay, from the lowest: compounds 3, 2 and 1 (each within the scatter of the next, the first and the last beyond it).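

In this assay, among these compounds, the group on the carbonyl carbon now gives a step beyond the scatter for the first time: 2-(trifluoromethyl)phenyl in place of 4-methoxyphenyl gives a 2.2-fold lower number from compound 1 to compound 3 (0.34 log units; beyond the scatter), a modest step. The other new step, 2-(trifluoromethyl)phenyl in place of 3-nitrophenyl, gives a 1.9-fold lower number from compound 2 to compound 3 (0.27 log units; within the scatter) and stays within the scatter, so this position shows some sensitivity to the aryl group, but only the two ends of the series can be told apart. Nothing available accounts for either step.

With the trifluoromethyl group seen at only one ring position and each aryl group seen once, the compounds shown cannot separate the effect of that group from the effect of where it sits, a question that 4-(trifluoromethyl)phenyl could address. Also open, from the compounds shown here alone, is whether an aromatic ring is needed on the carbonyl carbon at all, which a simple longer alkyl chain in its place would test, as would an amine or a carboxylic acid carried on the phenyl ring.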